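The compounds below may be only part of what the source reports. "The series", "measured", "known", "first", "only" and "open" are said of these compounds alone.

In a functional assay on NCI-H460 cells (Homo sapiens) for inhibition, with a stated time of 72 h (a lower number here means a stronger inhibitor, a higher number a weaker inhibitor), three compounds with a shared core differ only in one aromatic group. Compound 1 (`COc1ccc(S(=O)(=O)N2CCc3cccc(-c4ccc(F)nc4)c32)cc1`), with 6-fluoropyridin-3-yl, gives 135 nM. Compound 2 (`COc1ccc(S(=O)(=O)N2CCc3cccc(-c4ccco4)c32)cc1`), with furan-2-yl, gives 94.5 nM. Compound 3 (`COc1ccc(S(=O)(=O)N2CCc3cccc(-c4ccc([N+](=O)[O-])cc4)c32)cc1`), with 4-nitrophenyl, gives 53.1 nM. That value stands within the scatter of compound 2, as shown by a 1.8-fold lower number from compound 2 to compound 3 (0.25 log units; within the scatter), and clear of compound 1, as shown by a 2.5-fold lower number from compound 1 to compound 3 (0.41 log units; beyond the scatter).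

Compound 4 (`COc1ccc(S(=O)(=O)N2CCc3cccc(-c4ccc(N(C)C)cc4)c32)cc1`) has dimethylamino in place of nitro on an aromatic carbon, para to a large group: dimethylamino in place of nitro on an aromatic carbon. For the measured compounds named here, no measured pair tests this exact swap. The nearest evidence comes from replacing the whole aromatic group, which gave a 1.4-fold lower number from compound 1 to compound 2 (0.15 log units; within the scatter) as well as the two steps above. Even the largest of these is only modest, so no large change is expected here. The expected step, a 1.5-fold higher number from compound 3 to compound 4 (0.18 log units; within the scatter), is small and points towards a somewhat higher number, though with real uncertainty. Compound 4 is estimated at 80 nM, with an expected range of 25 nM to 250 nM.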

Compound 4, half-maximal inhibitory concentration: 556 nM
Beside the measured number, compound 4's estimate is 7.0-fold (0.84 log units) below it; measured number outside the range, above it.
By their numbers in this assay, from the lowest: compounds 3, 2 and 1 (each within the scatter of the next, the first and the last beyond it); then compound 4.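

Swapping the whole aromatic group among compounds 1, 2 and 3 moved the number only a little, yet a change to a single substituent on the ring has a much larger effect, with a 10-fold higher number from compound 3 to compound 4 (1.02 log units; beyond the scatter) in this assay. Compound 4 also stands apart from the two other compounds, with a 5.9-fold higher number from compound 2 to compound 4 (0.77 log units; beyond the scatter) and a 4.1-fold higher number from compound 1 to compound 4 (0.61 log units; beyond the scatter), which makes it the weakest inhibitor of the four. No evidence at hand explains why dimethylamino in place of nitro changes the number so strongly.

As far as these compounds go, it remains open whether this weaker result is specific to dimethylamino or would also appear with a primary amine or a methoxy group at the same place. From the compounds shown here alone, it is also open whether a nitrile or a carboxylic acid there would keep the number close to that of compound 3.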